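This account rests on a few compounds, and the source may have more. Where it says the series, first, only, none or still open, it means among the compounds named here.

Compound 3 `Nc1nc2cc(-c3nn(CCCCCC(=O)NO)c4ncnc(N)c34)ccc2o1` reaches a functional assay on A549 cells (Homo sapiens) for inhibition, read by MTT assay, with a stated time of 72 h (a lower number here means a stronger inhibitor, a higher number a weaker inhibitor), with a reading of > 100000 nM, which is a limit of the assay and not a number. Compound 2 `Nc1nc2cc(-c3nn(CCCCCCCCCC(=O)NO)c4ncnc(N)c34)ccc2o1`, which has the longer chain, gives > 50000 nM, and this too is a limit. The step that leads to compound 4 `CNC(=O)CCCCCCCn1nc(-c2ccc3oc(N)nc3c2)c2c(N)ncnc21` is 2-(methylcarbamoyl)ethyl in place of hydroxycarbamoyl on a saturated chain carbon, five bonds along the chain from an aromatic nitrogen.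

Among the measured compounds shown here, the one measured step that bears on this change is a step that the two limits leave unreadable from compound 2 to compound 3, so it offers no size to carry over. The better guide is compound 1 `CNC(=O)CCCCCCCn1nc(-c2cnc3[nH]ccc3c2)c2c(N)ncnc21`, which carries the same methylcarbamoyl chain as compound 4 on a different aromatic group. Compound 1 gives a true number of 51000 nM in this assay. For the measured compounds named here, that single value is the basis of the expectation, and no measured pair isolates the effect of the new chain end. The expected change is an at least 2.0-fold lower number from compound 3 to compound 4 (0.30 log units; that floor lies within the scatter), an estimate that remains loose since it starts from a limit. For compound 4 the estimated value is 50000 nM, with an expected range from 20000 nM to 100000 nM.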

Compound 4, half-maximal inhibitory concentration: 8360 nM
Compound 4: middle estimate off by 6.0-fold (0.78 log units), on the high side, outside the stated range (below it).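

In this assay, at this place on a saturated chain carbon, five bonds along the chain from an aromatic nitrogen, putting 2-(methylcarbamoyl)ethyl in place of hydroxycarbamoyl gives an at least 11-fold lower number from compound 3 to compound 4 (1.07 log units; beyond the scatter), and the change that also alters chain length gives an at least 5.9-fold lower number from compound 2 to compound 4 (0.77 log units; beyond the scatter). With the methylcarbamoyl chain held fixed, the change of aromatic group gives a 6.1-fold lower number from compound 1 to compound 4 (0.79 log units; beyond the scatter), so the aromatic group also moves the reading, which compound 1 alone could not show. The step from compound 3 gives only a floor on the size of the change, because compound 3 reads a limit and not a number: the limit of > 100000 nM in this assay, at which 1 of the 4 values shown sits.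

Going by these compounds, compound 2 likewise reads a limit and not a number, which leaves its step a floor as well: the limit of > 50000 nM in this assay, at which 1 of the 4 values shown sits. How far the two hydroxycarbamoyl compounds truly lie from compound 4 stays open, as does whether a carboxylic acid or a primary amide at the chain end, or a shorter chain ending in methylcarbamoyl, would read lower or higher than compound 4.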